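The source may hold more compounds than are shown below. What is called first, only, known or untested is meant among the compounds shown, and "the series" means these compounds.

Compound 1 `CCCCNc1nc(N)nc2c1CN(Cc1ccccc1Cl)CC2` carries a 2-chlorobenzyl group on the ring nitrogen of its shared core. In an assay on HEK293 cells for agonist activity at Toll-like receptor 8 (Homo sapiens), read by a luciferase reporter, with a stated time of 6 h (on this read-out lower numbers stand for an effect already at smaller amounts and higher numbers for an effect only at larger amounts of compound), compound 1 gives 0.05 uM. Within the data shown here, the only other measured compound, compound 2 `CCCCNc1nc(N)nc2c1CN(Cc1ccc(C(F)(F)F)cc1)CC2`, carries a different benzyl group and gives 0.23 uM in this assay. Compound 1 therefore stands at the lower of the two numbers. The gap to compound 2 lies beyond the usual scatter of repeated measurements.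

Compound 3 `CCCCNc1nc(N)nc2c1CN(Cc1ccco1)CC2` has not yet been measured. Its difference from compound 1 is furan-2-yl in place of 2-chlorophenyl on a saturated chain carbon bound to an amine nitrogen in a ring. Among the measured compounds shown here, only two measured compounds are available, and neither of them shows this kind of exchange, so the outlook rests on the change itself. A step toward higher numbers is expected, a 6.0-fold higher number from compound 1 to compound 3 (0.78 log units; beyond the scatter), as the large aromatic group that leaves is replaced by a smaller one. For compound 3 the estimated value in this assay is 0.3 uM, expected to fall between 0.06 uM and 1.5 uM.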

Compound 3, minimum effective concentration: 0.08 uM
Estimate against measurement, compound 3: 3.8-fold (0.57 log units) above; the range from low to high includes it.
By their numbers in this assay, from the lowest: compounds 1 and 3 (each within the scatter of the next); then compound 2.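

In this assay, furan-2-yl in place of 2-chlorophenyl on a saturated chain carbon bound to an amine nitrogen in a ring gives a 1.6-fold higher number from compound 1 to compound 3 (0.20 log units; within the scatter), so the two numbers cannot be told apart. The position therefore accepts a five-membered aromatic ring with one hetero atom as well as a six-membered aromatic ring of carbon only, and for this pair the chlorine is not needed to keep the number within the scatter. No measurement shown here gives a reason for this result.

Still open, from the compounds shown here alone, is what thiophene, pyridine or a saturated ring such as cyclohexyl would give on this carbon. Also open, going by these compounds, is whether a group with no ring at all, such as a plain propyl chain, would keep the number.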